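The source may hold more compounds than are shown below. What is called first, only, known or untested is meant among the compounds shown, and "the series" means these compounds.

Compound 1, with the structure `COc1ccc2oc(CSC(=S)N3CCOCC3)cc(=O)c2c1`, was tested in a functional assay on HEp-2 cells (Homo sapiens) for antiproliferative activity, read by MTT assay, with a stated time of 72 h (a lower number here means a stronger inhibitor, a higher number a weaker inhibitor), where compound 1 gives 3000 nM. Compound 2, with the structure `COc1ccc2oc(CSC(=S)N(C(C)C)C(C)C)cc(=O)c2c1`, gives 7600 nM in this assay. The change between them is diisopropylamino in place of morpholin-4-yl on a thiocarbonyl carbon and it made the step of a 2.5-fold higher number from compound 1 to compound 2 (0.40 log units; beyond the scatter). Compound 3, with the structure `O=c1c(CSC(=S)N2CCOCC2)coc2ccccc12`, has a different core; how the two cores differ is not broken down here. In this assay compound 3 gives 4400 nM, a number within the usual scatter of that of compound 1. Compound 4, with the structure `CC(C)N(C(=S)SCc1coc2ccccc2c1=O)C(C)C`, has not yet been measured. It differs from compound 3 by diisopropylamino in place of morpholin-4-yl on a thiocarbonyl carbon, the same change that was made from compound 1 to compound 2, at the same place. The step from compound 3 to compound 4 is expected to be about a 2.5-fold higher number from compound 3 to compound 4 (0.40 log units; beyond the scatter), similar in size to the earlier one, resting on a 2.5-fold higher number from compound 1 to compound 2 (0.40 log units; beyond the scatter). Compound 4 is therefore expected to give about 11000 nM in this assay. For compound 4 the number is estimated to fall most likely between 5000 nM and 25000 nM.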

Compound 4, half-maximal inhibitory concentration: 3000 nM
Beside the measured number, compound 4's estimate is 3.7-fold (0.56 log units) above it; the whole stated range lies above it.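

In this assay, putting diisopropylamino in place of morpholin-4-yl on the second core gives a 1.5-fold lower number from compound 3 to compound 4 (0.17 log units; within the scatter), so compound 3 and compound 4 cannot be told apart here. The change therefore did not carry over from one core to the other with the size it had on the first: the same change on two cores in this assay, a 2.5-fold higher number (0.40 log units; beyond the scatter) from compound 1 to compound 2 and a 1.5-fold lower number (0.17 log units; within the scatter) from compound 3 to compound 4, 3.7-fold (0.57 log units) apart, beyond the scatter of two such steps. Two pairs alone do not show which difference between the cores lies behind this, or how the change would behave on a further core.

The compounds shown leave open how other amines on the thiocarbonyl carbon, such as dimethylamino or piperidin-1-yl, would behave on either core. They also leave open whether either core would respond to those amines in the same way.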